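The source may hold more compounds than are shown below. What is called first, only, known or untested is meant among the compounds shown, and "the series" means these compounds.

Compound 1 `CN(C[C@H]1Cc2c(cccc2N2CCN(C3CC3)CC2)CN1)[C@H]1CCCc2cccnc21`: 15.5%
Compound 2 `CN1CCN(c2cccc3c2C[C@H](CN(C)[C@H]2CCCc4cccnc42)NC3)CC1`: 75.8%
Compound 3 `CN(C[C@H]1Cc2c(cccc2N2CCN(c3ncccn3)CC2)CN1)[C@H]1CCCc2cccnc21`: 35.5%

All three values come from an ADME assay on microsomes from liver (Homo sapiens) for metabolic stability, read by LC-MS, with a stated time of 10 min; on this read-out lower numbers stand for a less stable compound and higher numbers for a more stable compound. Compound 3 sits in the middle of the three numbers, higher than compound 1 and lower than compound 2, with both gaps beyond the scatter.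

The next compound is compound 4 `CN(C[C@H]1Cc2c(cccc2N2CCN(c3ccccn3)CC2)CN1)[C@H]1CCCc2cccnc21`, and the change is pyridin-2-yl in place of pyrimidin-2-yl on an amine nitrogen in a ring.

Three measured steps alter the group on that same ring nitrogen: a number 60.3 percentage points higher from compound 1 to compound 2 (beyond the scatter), a number 20 percentage points higher from compound 1 to compound 3 (beyond the scatter) and a number 40.3 percentage points lower from compound 2 to compound 3 (beyond the scatter). Two of these are large and one is modest, so this assay clearly responds to changes at this place. Each of them, however, has cyclopropyl or methyl at one end or both. Among the compounds with values here, none exchanges one six-membered aromatic ring for another, so the series holds no direct precedent for this swap.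

The closest reference is compound 3 at 35.5%. A small expected change, a number 5.5 percentage points lower from compound 3 to compound 4 (within the scatter), is the working assumption, and no step beyond the scatter is expected. The large step of a number 40.3 percentage points lower from compound 2 to compound 3 (beyond the scatter) at this nitrogen argues for a wide range all the same.

For compound 4 the estimated value is 30%, with an expected range from 13% to 50%.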

Compound 4, percent of the compound remaining: 27.4%
Compound 4: middle estimate off by 2.6 percentage points, on the high side, within the range that was stated.
By their numbers in this assay, from the lowest: compound 1; then compounds 4 and 3 (each within the scatter of the next); then compound 2.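

In this assay, exchanging pyrimidin-2-yl for pyridin-2-yl on the ring nitrogen gives a number 8.1 percentage points lower from compound 3 to compound 4 (within the scatter), so the series now has a direct comparison of two six-membered aromatic rings, and going from 2 hetero atoms to 1 does not separate them on this read-out. Compound 4 also stays well apart from the methyl compound, with a number 48.4 percentage points lower from compound 2 to compound 4 (beyond the scatter), and from the cyclopropyl compound, with a number 11.9 percentage points higher from compound 1 to compound 4 (beyond the scatter), which matches the direction and the modest size of a number 20 percentage points higher from compound 1 to compound 3 (beyond the scatter). Across these four compounds, methyl therefore gives the highest number, cyclopropyl the lowest, and the two aromatic rings fall together in the middle, with no compound shown going against this order.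

No measurement is available that bears on what underlies these differences at the ring nitrogen. On these data alone, it remains open where a phenyl ring, with no hetero atom, or a small open chain such as ethyl or isopropyl would fall relative to methyl and the two aromatic rings in this assay.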